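This account rests on a few compounds, and the source may have more. Where it says the series, first, only, none or still open, it means among the compounds named here.

Measured in an ADME assay on J744 cells (Mus musculus) for cytotoxicity, read by MTT assay, with a stated time of 48 h; a lower number here means a stronger inhibitor, a higher number a weaker inhibitor:
- Compound 1 `Cc1c(C(=O)N/N=C/c2ccc(N(C)C)cc2)no[n+]1[O-]`: 129000 nM
- Compound 2 `O=C(N/N=C/c1c(-c2ccccc2)no[n+]1[O-])c1cnn(-c2ccccc2)c1`: 42000 nM

Compound 1 has the higher of these two numbers, and its gap to compound 2 lies beyond the scatter, so compound 1 is the weaker inhibitor of the pair. Compound 3 `Cc1c(C(=O)N/N=C/c2ccc(C(=O)O)cc2)no[n+]1[O-]` has not yet been measured. It keeps the core of compound 1 but carries carboxy in place of dimethylamino on an aromatic carbon, para to a large group: carboxy in place of dimethylamino on an aromatic carbon. Among the measured compounds shown here, no two measured compounds differ in only one place, so the data offer no direct guide to this swap. With nothing to point either way, no step beyond the scatter is expected in this assay. The expected step, a 1.2-fold higher number from compound 1 to compound 3 (0.07 log units; within the scatter), is therefore a small one. For compound 3 the estimated value is 150000 nM, with an expected range of 60000 nM to 400000 nM.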

Compound 3, half-maximal inhibitory concentration: > 400000 nM
Compound 3 gave a limit, no number; the forecaster's own chance of this, stated with the estimate: 25%; middle value at least 2.6-fold (0.42 log units) away from the limit.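

Among the compounds shown here, this is the first direct view of the position para to a large group on the six-membered aromatic ring of carbon only. With the rest of compound 1 unchanged, putting carboxy in place of dimethylamino gives an at least 3.1-fold higher number from compound 1 to compound 3 (0.49 log units; beyond the scatter) in this assay, so the group at this position does affect the number, and here the change is toward a weaker inhibitor. The reading for compound 3 is a limit and not a number, so the true size of the step stays unknown: the limit of > 400000 nM in this assay, at which 1 of the 3 values shown sits.

Two groups alone cannot show whether the shift comes from gaining carboxy or from losing dimethylamino, and a methyl ester or a simple primary amine at this position would help separate the two. Going by these compounds, it also remains open whether the same swap would act alike on the core of compound 2.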